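The source may report more compounds than this note shows. Statements on the series, on what has been measured and on what is new or still open speak of the compounds shown alone.

Of the compounds shown here, two have been measured so far. Compound 1 `O=C(CN(c1ncnc2c1ncn2C1CCCCO1)C1CC1)NCC(=O)OCc1ccccc1` gives 55.7% in a functional assay on the whole organism (Tail, strain ICR) with Mus musculus as the target, in the tail flick test, with a stated time of 30 min, at a dose of 25 umol/kg by the oral route; on this read-out lower numbers stand for a weaker effect and higher numbers for a stronger effect at the one dose given. Compound 2 `NC(=O)C[C@H](NC(=O)CN(c1nc(Cl)nc2[nH]cnc12)C1CC1)C(=O)O` gives 29.7% in this assay, the lower of the two numbers, and its gap to compound 1 lies beyond the usual scatter of this kind of measurement. Compound 3 `CSCC[C@H](NC(=O)CN(c1nc(Cl)nc2[nH]cnc12)C1CC1)C(=O)O` has not yet been measured; it differs from compound 2 in one place: (methylsulfanyl)methyl in place of carbamoyl on a saturated chain carbon, two bonds along the chain from an amide-type nitrogen and a carbonyl carbon. Among the compounds with values here, no measured pair shows a change of this kind, so the step of a number 2.3 percentage points higher from compound 2 to compound 3 (within the scatter) is expected to stay within the scatter, with no clear direction. Compound 3 is estimated at 32%, between 15% and 55%.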

Compound 3, a percentage reported as activity, at one dose (the size of the read-out at that dose, not a potency): 20.4%
Compound 3: the middle estimate sits 11.6 percentage points above what was measured; low and high end bracket the measured number.
By their numbers in this assay, from the lowest: compounds 3 and 2 (each within the scatter of the next); then compound 1.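

In this assay the exchange of carbamoyl for (methylsulfanyl)methyl on this saturated chain carbon gives a number 9.3 percentage points lower from compound 2 to compound 3 (within the scatter) and thus no clear effect. At this position, a group with no hydrogen-bond donor and a group with one are not told apart by this single pair. Nothing available explains this result. Going by these compounds, whether an amine or a longer chain at this place would move the read-out beyond the scatter remains open. So does whether this exchange would give a similar result with other groups elsewhere on the molecule.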